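Chloro for Fluoro: a Clearance Step Still to Be Measured

The source may hold more compounds than are shown below. What is called first, only, known or untested is meant among the compounds shown, and "the series" means these compounds.

Measured so far:
compound 1, `CC(=O)N[C@@H]1CCC[C@H](C(=O)Nc2cc(-c3cnc4n3CCCC4)c(Cl)cn2)C1`, gives 12 uL/min in an ADME assay on cells (Hepatocyte, Rattus norvegicus) for metabolic stability, using equilibrium dialysis; on this read-out lower numbers stand for slow clearance and higher numbers for fast clearance
compound 2, `CC(=O)N[C@@H]1CCC[C@H](C(=O)Nc2cc(-c3cnn4c3CC(C)(C)C4)c(F)cn2)C1`, gives 81 uL/min in this assay

For the measured compounds named here, of the two numbers, compound 2 stands highest: its only neighbour, compound 1, sits well below it, and that gap lies beyond the usual scatter of the measurement. The two compounds, however, differ in more than one place at once, so no single change between them can be credited with the gap; their two values are all that can be said.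

Compound 3, `CC(=O)N[C@@H]1CCC[C@H](C(=O)Nc2cc(-c3cnn4c3CC(C)(C)C4)c(Cl)cn2)C1`, has not yet been measured. It departs from compound 2 at exactly one spot, and the change is chloro in place of fluoro on an aromatic carbon. Going by the values given here, no measured pair isolates this same swap, so there is nothing in the data to anchor a prediction of direction. On that footing a step from compound 2 to compound 3 of a 1.4-fold lower number from compound 2 to compound 3 (0.13 log units; within the scatter) is expected, no larger than the scatter. Compound 3 is therefore estimated to give 60 uL/min, within a range from 25 uL/min to 140 uL/min.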

Compound 3, intrinsic clearance in a liver preparation (reported as CLH), per the amount of preparation that the assay uses: 73 uL/min
Compound 3: the middle estimate sits 1.2-fold (0.09 log units) below what was measured; measured number inside the range.
By their numbers in this assay, from the lowest: compound 1; then compounds 3 and 2 (each within the scatter of the next).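

Chloro in place of fluoro on the aromatic carbon ortho to a large group gives a 1.1-fold lower number from compound 2 to compound 3 (0.05 log units; within the scatter) in this assay, so with the rest of the molecule held fixed, this position shows no clearance difference between the two halogens that can be told from the scatter. Compound 3 also gives the first single-change view of the earlier gap: with chloro on both sides, exchanging the group with a six-membered non-aromatic ring for the group with a five-membered non-aromatic ring on the aromatic carbon gives a 6.1-fold higher number from compound 1 to compound 3 (0.78 log units; beyond the scatter), a step beyond the scatter, so in this set the larger difference follows that group and not the halogen. Nothing available explains the size of either step.

For the compounds shown here, whether the two halogens also match when the group from compound 1 is present remains open, since this swap is seen with only one group. Also open, on these data alone, is how a methyl, a methoxy or a nitrile on the same aromatic carbon would compare with chloro and fluoro.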